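Thiophen-3-yl series: methylsulfanyl replacing dimethylamino

This account rests on a few compounds, and the source may have more. Where it says the series, first, only, none or still open, it means among the compounds named here.

Compound 1 `CN(C)c1ncnc2c1c(-c1ccsc1)cn2[C@@H]1O[C@H](CO)[C@@H](O)[C@H]1O` is the reference point. In a functional assay on HCT-116 cells (Homo sapiens), read by MTT assay, with a stated time of 72 h (on this read-out higher numbers stand for weaker inhibition and lower numbers for stronger inhibition), compound 1 gives > 20000 nM, which is a limit of the assay rather than a number. Compound 3 `CN(C)c1ncnc2c1c(-c1cccs1)cn2[C@@H]1O[C@H](CO)[C@@H](O)[C@H]1O` also gives > 20000 nM, likewise a limit. Compound 2 `C#Cc1cn([C@@H]2O[C@H](CO)[C@@H](O)[C@H]2O)c2ncnc(N(C)C)c12` gives 290 nM. The measured steps are an at least 68-fold lower number from compound 1 to compound 2 (1.83 log units; beyond the scatter), an at least 68-fold higher number from compound 2 to compound 3 (1.83 log units; beyond the scatter) and a step that the two limits leave unreadable from compound 1 to compound 3; the limit of > 20000 nM in this assay, at which 2 of the 3 values shown sit, frames all three. Compound 4 `CSc1ncnc2c1c(-c1ccsc1)cn2[C@@H]1O[C@H](CO)[C@@H](O)[C@H]1O` differs from compound 1 by methylsulfanyl in place of dimethylamino on an aromatic carbon, the thiophen-3-yl group staying in place. For the measured compounds named here, none of the measured steps touches the dimethylamino group, so none bears directly on this change, and the expectation rests on compound 1 alone: no shift beyond the scatter in this assay is expected. Compound 4 is estimated at 20000 nM, between 5000 nM and 60000 nM. That amounts to an expected a number no higher from compound 1 to compound 4 (the limit leaves the size open).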

Compound 4, half-maximal inhibitory concentration: > 20000 nM
Compound 4 gave a limit, no number; the forecaster's own chance of this, stated with the estimate: 70%; the middle value sits exactly at the limit.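

No new step can be read between compound 1 and compound 4, as both give a limit and not a number: the limit of > 20000 nM in this assay, at which 3 of the 4 values shown sit. The compounds shown leave open how methylsulfanyl compares with dimethylamino, with thiophen-3-yl or with the ethynyl group of compound 2.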